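The source may hold more compounds than are shown below. What is called first, only, known or untested is meant among the compounds shown, and "the series" means these compounds.

Working notes on the series.

Compound 3 `CNC(=O)c1cc(Oc2ccc3oc(Nc4ccc(C(C)C)cc4)nc3c2)ccn1` is the reference point for the next step. In an ADME assay on Caco-2 cells (Homo sapiens) for permeability, in the apical to basolateral direction (on this read-out higher numbers stand for higher permeability and lower numbers for lower permeability), compound 3 gives 10 10^-6 cm/s. Compound 1 `CCc1ccccc1Nc1nc2cc(Oc3ccnc(C(=O)NC)c3)ccc2o1` gives 10 10^-6 cm/s and compound 2 `CNC(=O)c1cc(Oc2ccc3oc(Nc4ccc(Br)cc4)nc3c2)ccn1` gives 10 10^-6 cm/s, so compound 3 sits level with both at the digits shown. The steps among the three are flat: no change at the digits printed from compound 1 to compound 2 (within the scatter), no change at the digits printed from compound 1 to compound 3 (within the scatter) and no change at the digits printed from compound 2 to compound 3 (within the scatter). All three compounds share the same core and differ only in the substituent on the aryl amine.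

Compound 4 `CNC(=O)c1cc(Oc2ccc3oc(Nc4ccc(N(C)C)cc4)nc3c2)ccn1` is the next compound, differing from compound 3 by dimethylamino in place of isopropyl on an aromatic carbon. The step from compound 2 to compound 3 bears most directly on this, since it also exchanged the group on an aromatic carbon of a six-membered aromatic ring of carbon only, para to a large group, and showed no change at the digits printed from compound 2 to compound 3 (within the scatter). The steps into compounds 2 and 3 from compound 1 were likewise flat. On that basis no movement beyond the scatter is expected in this assay for compound 4, and the expected step is no change at the digits printed from compound 3 to compound 4 (within the scatter). Compound 4 is therefore estimated at 10 10^-6 cm/s, with a range of 5 10^-6 cm/s to 20 10^-6 cm/s.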

Compound 4, apparent permeability: 10 10^-6 cm/s
Estimate against measurement, compound 4: no gap at the digits printed; the range from low to high includes it.
By their numbers in this assay, from the lowest: compounds 1, 2, 3 and 4 (each within the scatter of the next).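

In this assay, dimethylamino, which brings a nitrogen and a hydrogen-bond acceptor absent from isopropyl, leaves the read-out flat at this aromatic carbon (compare no change at the digits printed from compound 3 to compound 4 (within the scatter)), and the exchange for bromo reads the same (compare no change at the digits printed from compound 2 to compound 4 (within the scatter)). The wider exchange of 2-ethylphenyl for 4-(dimethylamino)phenyl on the nitrogen is also flat (compare no change at the digits printed from compound 1 to compound 4 (within the scatter)), so this exchange adds a heteroatom-bearing group to the substituents that show no step beyond the scatter. No measured evidence accompanies these values to account for the flat result.

Still open, from the compounds shown here alone, is whether a carboxylic acid, a primary amine or a longer chain at this place would give a step beyond the scatter in this assay. Going by these compounds, all four compounds also keep the shared core and its methyl amide, so the effect of replacing that amide with a carboxylic acid remains open.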